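A few compounds are considered here, and "the series" means these few. Any claim that something is new, unique, unknown or untested is made for them only; others in the source may bear on it.

Measured compounds:
- compound 1 `O=C(Nc1ccc(Cl)c(-c2nnc3c(Cl)cccn23)c1)c1ccc(C(F)(F)F)cc1Cl`: in a functional assay on A549 cells (Homo sapiens) for antiproliferative activity, read by MTT assay, with a stated time of 72 h (a lower number here means a stronger inhibitor, a higher number a weaker inhibitor), compound 1 gives > 100000 nM, a limit of the assay.
- compound 2 `Cc1nc(C(=O)Nc2ccc(Cl)c(-c3nnc4c(Cl)cccn34)c2)cs1`: in this assay compound 2 gives > 100000 nM, also a limit.
- compound 3 `O=C(Nc1ccc(Cl)c(-c2nnc3c(Cl)cccn23)c1)c1ccc(Cl)cc1`: in this assay compound 3 gives 73600 nM.

Compound 1 stands at the upper limit of this assay; no number is known for it, only that it sits where (the limit of > 100000 nM in this assay, at which 2 of the 3 values shown sit). Within the data shown here, the one computed step, an at least 1.3-fold lower number from compound 2 to compound 3 (0.13 log units; that floor lies within the scatter), moves from a limit to a number that is itself very weak, and it does not touch the part of the molecule changed here. The step to compound 4 `O=C(Nc1ccc(Cl)c(-c2nnc3c(Cl)cccn23)c1)c1ccc(Cl)cc1Cl` is chloro in place of trifluoromethyl on an aromatic carbon, a change on the ring attached to the carbonyl. Among the measured compounds shown here, no measured step bears on this change, so no direction beyond the scatter can be expected; the nearest measured neighbour, compound 3, is also very weak in this assay. Compound 4 is therefore expected to stay at or near the limit, estimated at 100000 nM (range 40000 nM to 300000 nM), a step of a number no higher from compound 1 to compound 4 (the limit leaves the size open).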

Compound 4, half-maximal inhibitory concentration: 61300 nM
For compound 4 the middle estimate is 1.6-fold (0.21 log units) above the measured one; the range from low to high includes it.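

In this assay, chloro in place of trifluoromethyl gives an at least 1.6-fold lower number from compound 1 to compound 4 (0.21 log units; that floor lies within the scatter), and 2,4-dichlorophenyl in place of 2-methyl-1,3-thiazol-4-yl gives an at least 1.6-fold lower number from compound 2 to compound 4 (0.21 log units; that floor lies within the scatter). Chloro in place of hydrogen on the same ring gives a 1.2-fold lower number from compound 3 to compound 4 (0.08 log units; within the scatter), so neither change at this position shows an effect beyond the scatter. The two steps that start from compound 1 and compound 2 give only a floor, as the starting values are limits and not numbers: the limit of > 100000 nM in this assay, at which 2 of the 4 values shown sit.

Going by these compounds, it stays open whether an amine or a carboxylic acid at this position would bring the number clearly below those of compound 3 and compound 4. On these data alone, it is equally open whether a methoxy group there would behave like chloro or trifluoromethyl.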